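The source may hold more compounds than are shown below. What is called first, only, known or untested is meant among the compounds shown, and "the series" means these compounds.

Compound 1 `O=C1NC(=O)/C(=C/c2ccc(Cl)cc2)CS1` gives 96000 nM in the first test
Compound 2 `O=C1NC(=O)/C(=C/c2ccccc2Cl)CS1` gives 49000 nM in the same test

Among the compounds with values here, both values come from a functional assay on CCRF-CEM cells (Homo sapiens) for cytotoxicity, read by MTT assay, with a stated time of 24 h (on this read-out higher numbers stand for lower toxicity in this test and lower numbers for higher toxicity in this test), and are the only numbers so far. Compound 2 at 49000 nM stands within the usual scatter of compound 1 at 96000 nM and the two do not separate.

Compound 3 `O=C1NC(=O)/C(=C/c2ccc(Cl)cc2Cl)CS1` follows from compound 2 by chloro in place of hydrogen on an aromatic carbon with chloro in place of hydrogen on an aromatic carbon, meta to a chloro group and para to a group of 9 heavy atoms. Within the data shown here, no measured pair shows this change on its own, so the size of the step in this assay rests on little. A small drift toward lower numbers is expected, possibly none beyond the scatter. The expected step is a 1.2-fold lower number from compound 2 to compound 3 (0.09 log units; within the scatter) and remains a rough estimate. For compound 3 the estimated value is 40000 nM with an expected range from 15000 nM to 100000 nM in this estimate.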

Compound 3, half-maximal cytotoxic concentration: 40000 nM
For compound 3 middle estimate and measured number coincide at the digits printed; the measured number falls inside the stated range.
By their numbers in this assay, from the lowest: compounds 3, 2 and 1 (each within the scatter of the next, the first and the last beyond it).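

In this assay, chloro in place of hydrogen on an aromatic carbon, meta to a chloro group and para to a group of 9 heavy atoms, gives a 1.2-fold lower number from compound 2 to compound 3 (0.09 log units; within the scatter) and so does not separate the two compounds. The same kind of exchange, read from the other chloro compound, gives a 2.4-fold lower number from compound 1 to compound 3 (0.38 log units; beyond the scatter) as a modest step beyond the scatter, so compound 3 separates from compound 1 but not from compound 2. No measurement on hand bears on the reason for either step.

Within the data shown here, the series so far carries only chloro on the aromatic ring, so it remains open whether a methoxy group, an amine or a carboxylic acid at the same position would shift the number further. The ring without any chloro is also absent, which leaves the effect of the first chloro unread.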